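The compounds below may be only part of what the source reports. "The series", "measured", "known", "first", "only" and "open" are said of these compounds alone.

Compound 1 `O=C(OC1CCC(CN2CCN(c3cc(=O)c4cc(C(F)(F)F)cc([N+](=O)[O-])c4s3)CC2)CC1)c1ccccc1` gives 0.603 h in an ADME assay on cells (Hepatocyte, Homo sapiens) for metabolic stability; a lower number here means that the compound disappears faster, a higher number that the compound lasts longer. Compound 2 `O=C(OC1CCC(CN2CCN(c3cc(=O)c4cc(C(F)(F)F)cc([N+](=O)[O-])c4s3)CC2)CC1)c1ccncc1` gives 0.075 h, and compound 3 `O=C(OC1CCC(CN2CCN(c3cc(=O)c4cc(C(F)(F)F)cc([N+](=O)[O-])c4s3)CC2)CC1)C1CCCCC1` gives 0.0967 h. On these numbers compound 3 stands second highest of the three: its gap to compound 2 lies within the scatter, while a 6.2-fold lower number from compound 1 to compound 3 (0.79 log units; beyond the scatter) lies beyond it. Compound 4 `O=C(OC1CCC(CN2CCN(c3cc(=O)c4cc(C(F)(F)F)cc([N+](=O)[O-])c4s3)CC2)CC1)c1ccc(F)cc1` carries 4-fluorophenyl in place of cyclohexyl on a carbonyl carbon. The step bearing most on this is a 6.2-fold lower number from compound 1 to compound 3 (0.79 log units; beyond the scatter), of which the present change is nearly the reverse with a fluorine added; an 8.0-fold lower number from compound 1 to compound 2 (0.91 log units; beyond the scatter) shows that not every aromatic ring at this place gives a number like that of compound 1. A rise in this assay toward the value of compound 1 is therefore expected, estimated at a 4.1-fold higher number from compound 3 to compound 4 (0.62 log units; beyond the scatter). Compound 4 is expected to give 0.4 h, within a range from 0.15 h to 1 h.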

Compound 4, half-life: 0.0983 h
The estimate for compound 4 lay 4.1-fold (0.61 log units) above the measured number; the whole stated range lies above it.
By their numbers in this assay, from the lowest: compounds 2, 3 and 4 (each within the scatter of the next); then compound 1.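

Read in this assay the steps of a 1.0-fold higher number from compound 3 to compound 4 (0.01 log units; within the scatter) and a 1.3-fold higher number from compound 2 to compound 4 (0.12 log units; within the scatter) place 4-fluorophenyl with cyclohexyl and pyridin-4-yl, so a six-membered aromatic ring of carbon only on this carbonyl carbon does not by itself keep the number of compound 1. Fluoro in place of hydrogen on an aromatic carbon alone gives a 6.1-fold lower number from compound 1 to compound 4 (0.79 log units; beyond the scatter) and so leaves compound 1 apart from the other three. Nothing measured here explains this step. From the compounds shown here alone, whether chloro, methyl or methoxy in place of that fluoro gives a number like compound 1 or like compound 4 stays open.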